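The source may hold more compounds than are shown below. What is called first, only, known or untested is meant among the compounds shown, and "the series" means these compounds.

Measured so far:
compound 1 `O=C(O)COc1ccc(NC(=O)COc2ccccc2)cc1F`: 29.8%
compound 2 `Cc1ccc(OCC(=O)Nc2ccc(OCC(=O)O)c(F)c2)cc1`: 31.2%
compound 3 `CC(C)c1cccc(OCC(=O)Nc2ccc(OCC(=O)O)c(F)c2)c1`: 43.3%

In a functional assay on CHO cells for agonist activity at Free fatty acid receptor 1 (Homo sapiens), read by FLIPR, tested at 100 nM (on this read-out higher numbers stand for a stronger effect at the one concentration tested and lower numbers for a weaker effect), compound 3 gives the highest of the three numbers. Compound 2 differs from compound 1 by methyl in place of hydrogen on an aromatic carbon, and this gave a number 1.4 percentage points higher from compound 1 to compound 2 (within the scatter). The cores of compound 1 and compound 3 differ by isopropyl in place of hydrogen on an aromatic carbon, a step of a number 13.5 percentage points higher from compound 1 to compound 3 (beyond the scatter) in this assay.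

Compound 4 `Cc1ccc(C(C)C)cc1OCC(=O)Nc1ccc(OCC(=O)O)c(F)c1` is not yet measured. It differs from compound 3 by methyl in place of hydrogen on an aromatic carbon. Around the place the surroundings differ: in compound 2 the methyl enters para to a large group, in compound 4 ortho to a large group and para to an isopropyl group, so this is the same kind of change, not the same. A step of about a number 1.7 percentage points higher from compound 3 to compound 4 (within the scatter) is expected, resting on the small size of a number 1.4 percentage points higher from compound 1 to compound 2 (within the scatter). For compound 4 an activity of 45% is estimated, between 33% and 57%.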

Compound 4, a percentage reported as activity, at one concentration (the size of the read-out at that concentration, not a potency): 14.6%
Compound 4: the middle estimate sits 30.4 percentage points above what was measured, and the stated range ends above it.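

On the core of compound 3, methyl in place of hydrogen on an aromatic carbon gave a number 28.7 percentage points lower from compound 3 to compound 4 (beyond the scatter) in this assay. Set beside the earlier case, this change does not carry over unchanged between the two cores: the same change on two cores in this assay, a number 1.4 percentage points higher (within the scatter) from compound 1 to compound 2 and a number 28.7 percentage points lower (beyond the scatter) from compound 3 to compound 4, 30.1 percentage points apart, beyond the scatter of two such steps

The small step on the core of compound 1 is therefore no guide to the core of compound 3, but one pair per core does not show whether the isopropyl group or the different place of the methyl, ortho to a large group, accounts for the gap. The compounds shown leave open whether a methyl ortho to a large group without the isopropyl group gives a similar drop, and whether a chlorine or methoxy group at that place behaves like methyl.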